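From Pyridin-2-yl to 3-Methylphenyl on a Shared Core

This account rests on a few compounds, and the source may have more. Where it says the series, first, only, none or still open, it means among the compounds named here.

Of the compounds shown here, two have been measured in an assay on isolated protein for inhibition of protein deacetylase HDAC6 (Homo sapiens); on this read-out higher numbers stand for weaker inhibition and lower numbers for stronger inhibition. Compound 1 `O=C(c1ccc(-c2nc(-c3ccccn3)no2)s1)C(F)(F)F` gives 500 nM, the lowest of the two numbers and hence the stronger inhibitor of the pair. Compound 2 `O=C(c1ccc(-c2ncc(-c3ccccc3)s2)s1)C(F)(F)F` gives 1350 nM, a weaker result whose gap from compound 1 lies beyond the usual scatter of this kind of measurement. Among the measured compounds shown here, no single-point step links these two structures, so the two numbers show only that compound 1 sits ahead.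

The untested compound 3 `Cc1cccc(-c2noc(-c3ccc(C(=O)C(F)(F)F)s3)n2)c1` keeps the core of compound 1 and changes one group: 3-methylphenyl in place of pyridin-2-yl on an aromatic carbon. One hydrogen-bond acceptor is lost and one carbon atom is gained in this exchange, while the rest of the molecule stays as it is.

For the measured compounds named here, with no measured step of this kind to lean on, only a modest shift is anticipated for compound 3 in this assay, leaning toward a somewhat higher number, and possibly no change beyond the scatter; the expected step is a 1.6-fold higher number from compound 1 to compound 3 (0.20 log units; within the scatter). The estimate for compound 3 in this assay is 800 nM, with a likely range from 300 nM to 2500 nM.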

Compound 3, half-maximal inhibitory concentration: 680 nM
Beside the measured number, compound 3's estimate is 1.2-fold (0.07 log units) above it; the measured number falls inside the stated range.
By their numbers in this assay, from the lowest: compounds 1, 3 and 2 (each within the scatter of the next, the first and the last beyond it).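

In this assay, among the compounds shown here, the exchange of pyridin-2-yl for 3-methylphenyl, on the aromatic carbon between two ring nitrogen atoms, is the first step here that alters a single place, and it reads as (a 1.4-fold higher number from compound 1 to compound 3 (0.13 log units; within the scatter)), so the two compounds cannot be told apart on this read-out. On the shared core, then, the nitrogen of pyridin-2-yl and its hydrogen-bond acceptor can be lost without a change beyond the scatter, as long as 3-methylphenyl takes its place, even though this group carries one more heavy atom. Nothing available here explains why these two groups read alike.

This single step alters two things together, the ring nitrogen and the methyl group, so plain phenyl at this position would be needed to show whether each alone leaves the number where it is, or whether the two effects happen to cancel. As far as these compounds go, both groups compared are also six-membered aromatic rings, so it stays open how this position responds to something of a different kind, such as an amine, a carboxylic acid or a longer chain.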